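The source may hold more compounds than are shown below. What is called first, only, known or untested is meant among the compounds shown, and "the series" means these compounds.

Measured in a functional assay on MCF7 cells (Homo sapiens) for antiproliferative activity, read by CellTiter-Glo, with a stated time of 5 days; a lower number here means a stronger inhibitor, a higher number a weaker inhibitor:
compound 1 `O=C(O)/C=C/c1ccc(/C(=C(\c2ccccc2)C2CCC2)c2ccc(-c3cncs3)cc2)cc1` gives 9.2 nM
compound 2 `N#Cc1cc(Cl)ccc1/C(=C(\c1ccc(/C=C/C(=O)O)cc1)c1ccc(-c2cncs2)cc1)C1CCC1` gives 4.3 nM
compound 3 `O=C(O)/C=C/c1ccc(/C(=C(\c2ccccc2)C2CCC2)c2ccc(-c3cn[nH]c3)cc2)cc1` gives 11 nM

Compound 3 has the highest number of the three, though its gap to one neighbour is small. The exchange of 1,3-thiazol-5-yl for 1H-pyrazol-4-yl on an aromatic carbon stays within the scatter (a 1.2-fold higher number from compound 1 to compound 3 (0.08 log units; within the scatter)). The value of compound 2 lies further down and beyond the scatter from compound 3, which reads 11 nM, while the lower figure of compound 2 reads 4.3 nM.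

Next in the series is compound 4 `N#Cc1cc(Cl)ccc1/C(=C(\c1ccc(/C=C/C(=O)O)cc1)c1ccc(-c2cn[nH]c2)cc1)C1CCC1`, with 4-chloro-2-cyanophenyl in place of phenyl on a double-bonded chain carbon bound to a double-bonded chain carbon and a saturated ring carbon. One measured step makes this same exchange, and it is modest (a 2.1-fold lower number from compound 1 to compound 2 (0.33 log units; beyond the scatter)). Among the compounds with values here, that step was seen with 1,3-thiazol-5-yl in the molecule, and no measurement yet shows whether it carries over to the 1H-pyrazol-4-yl series. The small step from compound 1 (a 1.2-fold higher number from compound 1 to compound 3 (0.08 log units; within the scatter)) gives no reason to expect a different outcome.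

Expected in this assay is a modest move to a lower number (a 2.1-fold lower number from compound 3 to compound 4 (0.33 log units; beyond the scatter)). For compound 4 the estimated value is 5.2 nM, with an expected range of 2.4 nM to 11 nM.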

Compound 4, half-maximal inhibitory concentration: 4.4 nM
Beside the measured number, compound 4's estimate is 1.2-fold (0.07 log units) above it, and the stated range covers the measured number.
By their numbers in this assay, from the lowest: compounds 2 and 4 (each within the scatter of the next); then compounds 1 and 3 (each within the scatter of the next).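

In this assay, 4-chloro-2-cyanophenyl in place of phenyl now also reads on the 1H-pyrazol-4-yl series, with a 2.5-fold lower number from compound 3 to compound 4 (0.40 log units; beyond the scatter), so this change on the double-bonded chain carbon is no longer tied to the 1,3-thiazol-5-yl series: the same change on two cores in this assay, a 2.1-fold lower number (0.33 log units; beyond the scatter) from compound 1 to compound 2 and a 2.5-fold lower number (0.40 log units; beyond the scatter) from compound 3 to compound 4, 1.2-fold (0.07 log units) apart, within the scatter of two such steps

The other exchange, 1H-pyrazol-4-yl in place of 1,3-thiazol-5-yl, now also reads with 4-chloro-2-cyanophenyl in the molecule, giving a 1.0-fold higher number from compound 2 to compound 4 (0.01 log units; within the scatter), and it stays within the scatter with either group at the other place: the same change on two cores in this assay, a 1.2-fold higher number (0.08 log units; within the scatter) from compound 1 to compound 3 and a 1.0-fold higher number (0.01 log units; within the scatter) from compound 2 to compound 4, 1.2-fold (0.07 log units) apart, within the scatter of two such steps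

Across these four compounds the two changes therefore read independently of each other, and none of the four goes against this.

The chlorine and the nitrile enter together in every pair shown, so their separate shares in the step remain open; 4-chlorophenyl and 2-cyanophenyl at this place would separate them. Going by these compounds, it is also open whether the insensitivity on the aromatic carbon extends beyond these two rings, for example to a primary amine or an amide there.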